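This account rests on a few compounds, and the source may have more. Where it says the series, first, only, none or still open, it means among the compounds named here.

The measured compounds:

Compound 1, `O=C(Nc1nnc(-c2ccc(Cl)cc2)s1)c1ccccc1O`, gives 1020 nM in a functional assay on MCF7 cells (Homo sapiens) for antiproliferative activity, read by MTT assay, with a stated time of 48 h; a lower number here means a stronger inhibitor, a higher number a weaker inhibitor.
Compound 2, `Cc1ccc(-c2nnc(NC(=O)c3ccccc3O)s2)cc1`, gives 2360 nM in this assay.
Compound 3, `O=C(Nc1nnc(-c2ccccc2)s1)c1ccc(Cl)cc1`, gives 4490 nM in this assay.

Compound 1 and compound 2 share one core and differ in a single place, where the difference is methyl in place of chloro on an aromatic carbon. This change brought a 2.3-fold higher number from compound 1 to compound 2 (0.36 log units; beyond the scatter), a modest weakening of the inhibitor.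

Compound 3 is built on a different core; how the core of compound 3 differs from the core of compound 1 is not broken down here. Compound 3 gives the highest number of the three. Its gap to compound 2 lies within the scatter, so no order between those two can be read. Its gap to compound 1 lies beyond the scatter, so compound 1 is clearly the stronger inhibitor of that pair in this assay.

Compound 4, `Cc1ccc(C(=O)Nc2nnc(-c3ccccc3)s2)cc1`, has not yet been measured. It differs from compound 3 by methyl in place of chloro on an aromatic carbon. This is the same change already seen between compound 1 and compound 2, at a place described in identical words, though on a different core.

Because the earlier step gave a 2.3-fold higher number from compound 1 to compound 2 (0.36 log units; beyond the scatter), a step of about a 2.1-fold higher number from compound 3 to compound 4 (0.33 log units; beyond the scatter) is expected here. The expectation rests on that single earlier pair, and a different core may not respond in the same way, so the range is kept wide. Compound 4 is therefore estimated to give about 9500 nM in this assay, with a likely span from 3500 nM to 26000 nM.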

Compound 4, half-maximal inhibitory concentration: 3280 nM
Compound 4: the middle estimate sits 2.9-fold (0.46 log units) above what was measured; the whole stated range lies above it.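

In this assay, methyl in place of chloro on the second core brings a 1.4-fold lower number from compound 3 to compound 4 (0.14 log units; within the scatter) and so leaves no order to read within this pair. For the compounds shown here, this does not show why the two cores behave differently: each core offers only a single pair, which is too little to tell which feature of a core matters or how a third core would respond. What it does show is that the step seen on the core of compound 1 cannot simply be carried over to the core of compound 3, since the two steps differ by more than the usual spread of such measurements, even though the swap of groups is described in identical words:
the same change on two cores in this assay, a 2.3-fold higher number (0.36 log units; beyond the scatter) from compound 1 to compound 2 and a 1.4-fold lower number (0.14 log units; within the scatter) from compound 3 to compound 4, 3.2-fold (0.50 log units) apart, beyond the scatter of two such steps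

Still open, on these data alone, is how other groups at the same place on the ring, such as fluoro, methoxy, an amine, a carboxylic acid or a longer chain like butyl, would behave on each of the two cores. Also open, as far as these compounds go, is whether the contrast between the two cores would appear again with a further pair of groups, or would hold in cells other than those of this assay.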